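The source may hold more compounds than are shown below. What is called first, only, known or untested is meant among the compounds shown, and "the series" means these compounds.

Measured so far:
compound 1, `CC1(C)CC(NC(=O)Nc2ccccc2)c2cc(Cl)ccc2O1`, in a functional assay (aorta) with Rattus norvegicus as the target (a lower number here means that less compound is needed, a higher number that more compound is needed for the effect), gives 7800 nM.
compound 2, `Cc1ccccc1NC(=O)NC1CC(C)(C)Oc2ccc(Cl)cc21`, reaches in this assay only a limit: > 10000 nM.
compound 3, `Cc1cccc(NC(=O)NC2CC(C)(C)Oc3ccc(Cl)cc32)c1`, reaches in this assay only a limit: > 10000 nM.

Compound 3 therefore stands at a limit of this assay and has no number of its own. Compound 4, `Cc1ccc(NC(=O)NC2CC(C)(C)Oc3ccc(Cl)cc32)cc1`, differs from it by 4-methylphenyl in place of 3-methylphenyl on an amide-type nitrogen. For the measured compounds named here, the steps that bear on this change are an at least 1.2-fold higher number from compound 1 to compound 2 (0.10 log units; that floor lies within the scatter) and an at least 1.2-fold higher number from compound 1 to compound 3 (0.10 log units; that floor lies within the scatter), both adding a methyl on an aromatic carbon, and a step that the two limits leave unreadable from compound 2 to compound 3, which moves that methyl but cannot be read because of the limit of > 10000 nM in this assay, at which 2 of the 3 values shown sit. With two of three values at the limit, compound 4 is expected to stay at or near it, with a step that the limit leaves unreadable from compound 3 to compound 4. The estimate for compound 4 is 12000 nM, ranging from 4000 nM to 40000 nM.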

Compound 4, half-maximal effective concentration: > 30000 nM
Compound 4 was reported as a limit; the forecaster's own chance of this, stated with the estimate: 65%; middle value at least 2.5-fold (0.39 log units) away from the limit.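

In this assay compound 4 reaches only a limit, > 30000 nM. It gives the first methyl addition whose size clears the scatter, with 4-methylphenyl on the amide-type nitrogen: an at least 3.8-fold higher number from compound 1 to compound 4 (0.58 log units; beyond the scatter). The steps among compound 2, compound 3 and compound 4 cannot be read, as all three stand at limits: the limit of > 30000 nM in this assay, at which 1 of the 4 values shown sits.

Going by these compounds, how the three methylphenyl compounds rank against one another therefore remains open. Also open, on these data alone, is how an amine or a carboxylic acid in place of that methyl would read in this assay.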